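The source may report more compounds than this note shows. Statements on the series, on what has been measured and on what is new or still open speak of the compounds shown alone.

Measured in a functional assay on UACC-62 cells (Homo sapiens) for cytotoxicity, read by sulforhodamine B assay; a higher number here means that more compound is tolerated, a lower number that less compound is tolerated:
Compound 1, `CC1=CC[C@@H]([C@@](C)(O)CCCC(C)(C)NC(=S)N/N=C\c2ccccc2)CC1`: 48400 nM
Compound 2, `CC1=CC[C@@H]([C@@](C)(O)CCCC(C)(C)NC(=S)N/N=C\c2ccc([N+](=O)[O-])cc2)CC1`: > 100000 nM

For compound 2 the reading > 100000 nM is a limit and not a number. Compound 3, `CC1=CC[C@@H]([C@@](C)(O)CCCC(C)(C)NC(=S)N/N=C\c2ccc(Cl)cc2)CC1`, has yet to be measured. It keeps the shared core of compound 2 and carries chloro in place of nitro on an aromatic carbon. Within the data shown here, only one measured step bears on this change, an at least 2.0-fold higher number from compound 1 to compound 2 (0.31 log units; beyond the scatter), where nitro replaced hydrogen at the same place. That step is at least modest, but its true size is open. Among the measured compounds shown here, no chloro compound has been measured, so its effect is unknown. Losing the nitro group is therefore expected to give back most of that step, moving this assay towards a lower number, close to the level of compound 1. The expected change is an at least 1.8-fold lower number from compound 2 to compound 3 (0.25 log units; that floor lies within the scatter). The estimate for compound 3 is 55000 nM, with an expected range from 25000 nM to 110000 nM.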

Compound 3, concentration lethal to 50% of the cells: 40600 nM
The estimate for compound 3 lay 1.4-fold (0.13 log units) above the measured number; the range from low to high includes it.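

In this assay, chloro in place of nitro on the aromatic carbon gives an at least 2.4-fold lower number from compound 2 to compound 3 (0.39 log units; beyond the scatter), so this swap undoes the shift seen when nitro entered at that place. Chloro in place of hydrogen gives a 1.2-fold lower number from compound 1 to compound 3 (0.08 log units; within the scatter), which shows that a substituent at this place need not move the reading: among these three compounds, only the 4-nitrophenyl compound, compound 2, stands apart. Compound 2 reads as a limit and not a number, so the true size of the step to compound 3 stays open: the limit of > 100000 nM in this assay, at which 1 of the 3 values shown sits.

Going by these compounds, whether other groups at this place, such as an amine, a methoxy group or a carboxylic acid, would stay level with hydrogen and chloro or stand apart like nitro remains open. On these data alone, it is also open whether the same changes would read alike with a longer chain in the shared core.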